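Shifting a halogen on the naphthalene ring

The source may report more compounds than this note shows. Statements on the series, on what has been measured and on what is new or still open speak of the compounds shown alone.

Among the measured compounds shown here, compound 2 `Cc1cc(S(N)(=O)=O)ccc1NC(=O)COc1ccc(Cl)cc1Oc1ccc2cc(Br)ccc2c1` stands lowest of the two numbers so far in an ADME assay on C8166 cells (Homo sapiens) for cytotoxicity, read by MTT assay (a higher number here means that more compound is tolerated, a lower number that less compound is tolerated), where compound 2 gives 31300 nM. Compound 1 `Cc1cc(S(N)(=O)=O)ccc1NC(=O)COc1ccc(Cl)cc1Oc1ccc2ccccc2c1` gives 119000 nM in this assay. For the measured compounds named here, the one measured step, a 3.8-fold lower number from compound 1 to compound 2 (0.58 log units; beyond the scatter), shows that adding a halogen to the naphthalene ring lowered the number. Compound 3 `Cc1cc(S(N)(=O)=O)ccc1NC(=O)COc1ccc(Cl)cc1Oc1ccc2ccccc2c1Cl` carries a different halogen at a different position: 1-chloronaphthalen-2-yl in place of 6-bromonaphthalen-2-yl on an oxygen on an aromatic ring. Going by the values given here, no measured step covers a swap of one halogen for another, so the expectation rests loosely on compound 2, whose value of 31300 nM already holds a halogen, and on compound 1, whose value of 119000 nM holds none. The step of a 1.4-fold higher number from compound 2 to compound 3 (0.16 log units; within the scatter) is therefore expected to stay small, likely within the scatter. Compound 3 is estimated at 45000 nM, with a range from 15000 nM to 130000 nM.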

Compound 3, half-maximal cytotoxic concentration: 40700 nM
For compound 3 the middle estimate is 1.1-fold (0.04 log units) above the measured one; measured number inside the range.
By their numbers in this assay, from the lowest: compounds 2 and 3 (each within the scatter of the next); then compound 1.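

In this assay the change from 6-bromonaphthalen-2-yl to 1-chloronaphthalen-2-yl gives a 1.3-fold higher number from compound 2 to compound 3 (0.11 log units; within the scatter) and so the two groups cannot be told apart here, even though both the halogen and its place on the ring differ. Chloro in place of hydrogen gives a 2.9-fold lower number from compound 1 to compound 3 (0.47 log units; beyond the scatter) and so a second halogen-bearing compound lies beyond the scatter from compound 1, which shows that the lower number is not tied to bromine or to a single place on the ring. Nothing available explains why these two halogens give such similar numbers.

As far as these compounds go, whether a fluoro or a methoxy group on the same ring would give a similar number stays open. From the compounds shown here alone, it is also open whether chloro and bromo would match at one and the same place, as halogen and place vary together here.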